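The source may hold more compounds than are shown below. What is called first, only, known or untested is meant among the compounds shown, and "the series" means these compounds.

Of the compounds shown here, two have been measured. Compound 1 `C=CC(=O)Nc1cc(Nc2nccc(NC(=O)c3ccc(C(F)(F)F)cc3)n2)c(OC)cc1N(C)CCN(C)C` gives 9880 nM in a functional assay on A549 cells (Homo sapiens) for antiproliferative activity, read by MTT assay, with a stated time of 72 h; a lower number here means a stronger inhibitor, a higher number a weaker inhibitor. Compound 2 `C=CC(=O)Nc1cc(Nc2nccc(NC(=O)c3ccccc3)n2)c(OC)cc1N1CCN(C)CC1` gives 5970 nM in this assay. The two numbers lie within the usual scatter of each other, so neither compound can be called the stronger or the weaker inhibitor on these data; both are weak inhibitors on this scale.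

Compound 3 `C=CC(=O)Nc1cc(Nc2nccc(NC(=O)c3ccc(C(F)(F)F)cc3)n2)c(OC)cc1N1CCN(C)CC1` has not yet been measured. It differs from compound 2 in a single place: trifluoromethyl in place of hydrogen on an aromatic carbon. For the measured compounds named here, the same trifluoromethyl group is present in compound 1, but compound 1 also differs from compound 2 elsewhere, so no single step tells what the trifluoromethyl group alone does here.

With only that to go on, the step of a 1.2-fold higher number from compound 2 to compound 3 (0.07 log units; within the scatter) is expected to be small, in no particular direction, and not beyond the scatter, because compound 1 with the same trifluoromethyl group gives 9880 nM. Compound 3 is therefore estimated at 7000 nM in this assay, within a range from 3000 nM to 16000 nM.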

Compound 3, half-maximal inhibitory concentration: 7890 nM
Estimate against measurement, compound 3: 1.1-fold (0.05 log units) below; low and high end bracket the measured number.
By their numbers in this assay, from the lowest: compounds 2, 3 and 1 (each within the scatter of the next).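

In this assay, for the compounds shown here, trifluoromethyl in place of hydrogen on the aromatic carbon of the benzoyl group gives a 1.3-fold higher number from compound 2 to compound 3 (0.12 log units; within the scatter) and, seen alone for the first time, this change cannot be told apart from the spread of repeated measurements. With the trifluoromethyl group kept, 4-methylpiperazin-1-yl in place of (2-(dimethylamino)ethyl)(methyl)amino gives a 1.3-fold lower number from compound 1 to compound 3 (0.10 log units; within the scatter), so the second place that separated compound 1 from compound 2 can now also be read alone, and it too shows no clear difference. No other measurement is available to explain either result.

Still open, on these data alone, is whether a different group at the benzoyl position, such as an amine, a carboxylic acid or a longer chain, would move the number beyond the scatter, since going from hydrogen to trifluoromethyl says little about other kinds of group. Also open, as far as these compounds go, is how hydrogen at that position would read alongside (2-(dimethylamino)ethyl)(methyl)amino, a pairing that would test whether the two places act independently of each other.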